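A few compounds are considered here, and "the series" means these few. Any claim that something is new, unique, unknown or untested is made for them only; others in the source may bear on it.

Measured so far:
compound 1 `O=C(NC1CCCC1)c1ccc(C#Cc2cccnc2)nc1`, an assay on HEK293 cells for displacement of a labelled ligand from metabotropic glutamate receptor 5 (Homo sapiens), with a stated time of 2 h; a higher number here means a weaker inhibitor, a lower number a stronger inhibitor: > 32000 nM
compound 2 `CC(C)N1CCc2nc(C#Cc3ccccc3)ccc2C1=O`, this assay: 1280 nM

Going by the values given here, only two compounds have been measured, and they sit on different cores, so no one-step comparison links them. Among the compounds with values here, for compound 1 the value in this assay is a limit, not a number; it tells only that compound 1 was not seen to bind within the range tested (the limit of > 32000 nM in this assay, at which 1 of the 2 values shown sits). Within the data shown here, compound 2 gives the only real number in this assay, so it stands alone as the point of reference. Compound 3 `CC(C)N1CCc2nc(C#Cc3ccccn3)ccc2C1=O` is the next step from compound 2: pyridin-2-yl in place of phenyl on a triple-bonded carbon. The change keeps the shared core and the alkyne, and swaps one six-membered aromatic ring for another. Among the measured compounds shown here, with no measured step of this kind available, the expected change from compound 2 to compound 3 in this assay is modest, a 1.4-fold higher number from compound 2 to compound 3 (0.15 log units; within the scatter), with no firm direction. Compound 3 is therefore estimated at 1800 nM, likely between 400 nM and 8000 nM.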

Compound 3, inhibition constant: 2740 nM
Compound 3: the middle estimate sits 1.5-fold (0.18 log units) below what was measured; the range from low to high includes it.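

Going by these compounds alone, replacing phenyl with pyridin-2-yl on a triple-bonded carbon gives the first step that can be read in this assay: a 2.1-fold higher number from compound 2 to compound 3 (0.33 log units; beyond the scatter). This shows that the ring at this position can take a nitrogen atom in place of a carbon, at a modest cost in binding, and that compound 3 still gives a real number rather than a limit. The compounds shown offer nothing that explains this modest loss.

Going by these compounds, it remains open whether a different ring at this position, such as a pyrimidin-2-yl ring or a phenyl ring carrying a fluorine atom or a methoxy group, would bind more tightly than compound 2, which gives 1280 nM. It is also unknown how much of the binding depends on the group on the amide nitrogen of the shared core, which a cyclopropyl group could test.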